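Taking one hydroxy away from a dihydroxy chalcone-like compound

The compounds below may be only part of what the source reports. "The series", "measured", "known", "first", "only" and "open" are said of these compounds alone.

Compound 1 `Cn1c(/C=C/C(=O)c2ccccc2)cc(Br)c1Br`: >= 100000 nM
Compound 2 `Cn1c(/C=C/C(=O)c2ccc(O)cc2O)cc(Br)c1Br`: 830 nM

Of the compounds shown here, two have been measured in a functional assay on PA-1 cells (Homo sapiens) for cytotoxicity, read by MTT assay, with stated times of 6 h and 48 h; a higher number here means a weaker inhibitor, a lower number a stronger inhibitor. Going by the values given here, compound 2 gives 830 nM, the only true number so far, so it cannot yet be ranked against another measured value. Compound 1, which carries no hydroxy group, gives >= 100000 nM, and this is a limit of the assay and not a number.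

The next compound is compound 3 `Cn1c(/C=C/C(=O)c2ccc(O)cc2)cc(Br)c1Br`. It differs from compound 2 as follows: hydrogen in place of hydroxy on an aromatic carbon. Hydrogen stands in place of hydroxy on an aromatic carbon, ortho to a large group and meta to a hydroxy group. Among the compounds with values here, no measured pair isolates this change, so any forecast is loose. Compound 3 keeps one hydroxy group and so lies structurally between the two measured compounds. A move towards weaker inhibition, beyond the scatter, is therefore expected from compound 2 at 830 nM. The expected size is a 7.2-fold higher number from compound 2 to compound 3 (0.86 log units; beyond the scatter). For compound 3 the estimate is 6000 nM, with an expected range of 1500 nM to 40000 nM.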

Compound 3, half-maximal inhibitory concentration: 2850 nM
For compound 3 the middle estimate is 2.1-fold (0.32 log units) above the measured one, within the range that was stated.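

In this assay, the step of a 3.4-fold higher number from compound 2 to compound 3 (0.54 log units; beyond the scatter) shows that the hydroxy group ortho to a large group and meta to a hydroxy group does count, since the step lies beyond the scatter, but it is only a modest step and compound 3 stays clearly measurable without that group. The other listed step, with hydroxy in place of hydrogen on an aromatic carbon, is large, an at least 35-fold lower number from compound 1 to compound 3 (1.54 log units; beyond the scatter), so in these compounds the single hydroxy group kept in compound 3 accounts for much more of the change than the one lost from compound 2. The true size of that large step remains unknown, because compound 1 stands at a limit of the assay and not at a number: the limit of >= 100000 nM in this assay, at which 1 of the 3 values shown sits.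

The compounds shown leave open whether a methoxy group or an amine in this place would behave like the hydroxy group of compound 2 or like the hydrogen of compound 3. They also leave open whether the hydroxy group kept in compound 3 would give a similar gain from another carbon of the same ring.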